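The source may hold more compounds than are shown below. What is called first, only, known or untested is meant among the compounds shown, and "the series" means these compounds.

Measured in a functional assay on RAW264.7 cells (Mus musculus) for inhibition, read by Griess assay, with stated times of 1 h and 24 h; a lower number here means a stronger inhibitor, a higher number a weaker inhibitor:
Compound 1 `COc1ccc(C(O)C2OC(=O)c3c(OC)cc(OC)cc32)cc1`: > 10000 nM
Compound 2 `COc1cc(OC)c2c(c1)C(C(O)c1ccc(OCc3ccccc3)cc1)OC2=O`: > 10000 nM

Compound 1 gives > 10000 nM, which is a limit and not a number. Compound 2 gives > 10000 nM, which is also only a limit. Compound 2 therefore stands at the limit of > 10000 nM in this assay, at which 2 of the 2 values shown sit.

Compound 3 `COc1cc(OC)c2c(c1)C(C(O)c1ccc(OCc3ccc(Cl)cc3)cc1)OC2=O` is built from compound 2 by one small change: chloro in place of hydrogen on an aromatic carbon. Chloro takes the place of hydrogen on an aromatic carbon, so that benzyloxy becomes (4-chlorobenzyl)oxy.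

Among the compounds with values here, the only measured step that bears on this is a step that the two limits leave unreadable from compound 1 to compound 2. It offers no size and no direction to carry over, so no change beyond the usual scatter is expected in this assay. The expected result is a step that the limit leaves unreadable from compound 2 to compound 3. For compound 3 the estimated value is 14000 nM, with an expected range from 4000 nM to 40000 nM.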

Compound 3, half-maximal inhibitory concentration: 4320 nM
The estimate for compound 3 lay 3.2-fold (0.51 log units) above the measured number; measured number inside the range.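

In this assay, the earlier compounds gave only limits, so the step between them cannot be read and nothing could be said about this part of the molecule: the limit of > 10000 nM in this assay, at which 2 of the 3 values shown sit.

Chloro on the aromatic carbon, para to a large group, now shows that this position can respond to a change, with an at least 2.3-fold lower number from compound 2 to compound 3 (0.36 log units; beyond the scatter). The wider comparison, with 4-chlorophenyl in place of hydrogen, gives an at least 2.3-fold lower number from compound 1 to compound 3 (0.36 log units; beyond the scatter), and both sizes are only minimum sizes, as each starting value is a limit.

The compounds shown leave open whether the gain is specific to chloro or would also appear with a methyl, a methoxy or an amine in the same place. They also leave open how much of the gain depends on the benzyloxy chain that carries the chloro.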